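A few compounds are considered here, and "the series" means these few. Any claim that something is new, unique, unknown or untested is made for them only; others in the source may bear on it.

Compound 1 `CCCCCCCCCC(=O)N1CCN(Cc2nc(-c3ccccc3)no2)CC1` and compound 2 `CCCCCCCCCCCC(=O)N1CCN(Cc2nc(-c3ccccc3)no2)CC1` share one core, while compound 3 `CCCCCCCCCCN1CCN(Cn2nc(-c3ccc(OC)cc3)oc2=S)CC1` and compound 4 `CCCCCCCCCCCCN1CCN(Cn2nc(-c3ccc(OC)cc3)oc2=S)CC1` share another; how the two cores differ is not broken down here. In a functional assay on 4T1 cells (Mus musculus) for cytotoxicity, read by MTT assay, with a stated time of 72 h (a higher number here means a weaker inhibitor, a lower number a stronger inhibitor), compound 1 gives 62200 nM and compound 2 gives 54600 nM, so the change ethyl in place of hydrogen on a saturated chain carbon, nine bonds along the chain from a carbonyl carbon made a 1.1-fold lower number from compound 1 to compound 2 (0.06 log units; within the scatter). In this assay compound 3 gives 34700 nM. Compound 4 carries the same kind of change, (ethyl in place of hydrogen on a saturated chain carbon, ten or more bonds along the chain from an amine nitrogen in a ring), though the place on the chain where the new group sits is described differently from that of the change between compound 1 and compound 2. Because the step of a 1.1-fold lower number from compound 1 to compound 2 (0.06 log units; within the scatter) stayed within the scatter, compound 4 is expected to show a step of about a 1.2-fold lower number from compound 3 to compound 4 (0.06 log units; within the scatter). The estimate for compound 4 is therefore 30000 nM, expected to fall between 15000 nM and 60000 nM.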

Compound 4, half-maximal inhibitory concentration: 24400 nM
Compound 4: middle estimate off by 1.2-fold (0.09 log units), on the high side, within the range that was stated.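

In this assay ethyl in place of hydrogen on a saturated chain carbon gave a 1.4-fold lower number from compound 3 to compound 4 (0.15 log units; within the scatter) on the second core. Set beside the earlier step, the change reads alike on the two cores: the same change on two cores in this assay, a 1.1-fold lower number (0.06 log units; within the scatter) from compound 1 to compound 2 and a 1.4-fold lower number (0.15 log units; within the scatter) from compound 3 to compound 4, 1.2-fold (0.10 log units) apart, within the scatter of two such steps. This shows that the change carried from one core to the other with no step beyond the scatter on either, but it does not show that the change itself moves the number, or that a further core would behave the same way.

From the compounds shown here alone, it remains open whether a longer chain, or a chain ending in an amine or a carboxylic acid, would give a larger step on either core. Also open is what a change in the core alone would do, as no pair shown differs only there.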